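This account rests on a few compounds, and the source may have more. Where it says the series, first, only, none or still open, it means among the compounds named here.

Measured in a functional assay on A549 cells (Homo sapiens) for antiproliferative activity, read by MTT assay, with a stated time of 48 h; a lower number here means a stronger inhibitor, a higher number a weaker inhibitor:
- compound 1 `C=C(c1cc(OC)c(OC)c(OC)c1)c1ccc(OC)cc1NC(=O)CNC`: 100 nM
- compound 2 `C=C(c1cc(OC)c(OC)c(OC)c1)c1ccc(OC)cc1NC(=O)CNCC`: 260 nM

Of the two compounds, compound 2 has the higher number, at 260 nM. Compound 3 `C=C(c1cc(OC)c(OC)c(OC)c1)c1ccc(OC)cc1NC(=O)CN(C)C` is the next to be read: dimethylamino in place of ethylamino on a saturated chain carbon bound to a carbonyl carbon. That is dimethylamino in place of ethylamino on a saturated chain carbon bound to a carbonyl carbon, with the same atoms joined differently. Among the measured compounds shown here, only one measured step bears on this change: a 2.6-fold higher number from compound 1 to compound 2 (0.41 log units; beyond the scatter). That step is modest, and it shows the number responding to a small change in this amino group. It does not settle the direction for the new arrangement, so the expectation is tentative. For the measured compounds named here, a modest move towards a lower number is expected, no larger than that step, and the estimated step is a 1.6-fold lower number from compound 2 to compound 3 (0.21 log units; within the scatter). The estimate for compound 3 is 160 nM, with an expected range of 60 nM to 420 nM.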

Compound 3, half-maximal inhibitory concentration: 130 nM
Compound 3: the middle estimate sits 1.2-fold (0.09 log units) above what was measured; the measured number falls inside the stated range.
By their numbers in this assay, from the lowest: compounds 1, 3 and 2 (each within the scatter of the next, the first and the last beyond it).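

In this assay, swapping ethylamino for dimethylamino on a saturated chain carbon bound to a carbonyl carbon gives a 2.0-fold lower number from compound 2 to compound 3 (0.30 log units; within the scatter), so this rearrangement of the same atoms does not move the number beyond the scatter. Placed on the amine nitrogen, the added methyl gives a 1.3-fold higher number from compound 1 to compound 3 (0.11 log units; within the scatter), whereas on the saturated chain carbon bound to an amine nitrogen it gives a 2.6-fold higher number from compound 1 to compound 2 (0.41 log units; beyond the scatter); in this set, a dimethylamino group with no hydrogen-bond donor therefore stays within the scatter of the methylamino group of compound 1. No measurement here explains the difference between these two methyl steps.

Going by these compounds, a primary amine, a longer chain on the nitrogen and ring amines such as pyrrolidine or morpholine remain open at this place. With only three small amino groups shown, no trend with the size of the group can be drawn.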